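The compounds below may be only part of what the source reports. "The series", "measured", "known", "first", "only" and "open" are said of these compounds alone.

Measured so far:
compound 1, `CCNC(=O)c1sc2ncnc(Nc3cc(C)cn(C)c3=O)c2c1C`, > 10000 nM
compound 2, `COC(=O)c1sc2ncnc(Nc3ccc(=O)n(C)c3)c2c1C`, > 10000 nM

In an assay on isolated protein for inhibition of MAP kinase-interacting serine/threonine-protein kinase 1 (Homo sapiens), read by ADP-Glo, with a stated time of 10 min (a higher number here means a weaker inhibitor, a lower number a stronger inhibitor), compound 1 gives > 10000 nM, which is a limit of the assay and not a number. In this assay compound 2 gives > 10000 nM, again a limit rather than a number. Compound 2 thus stands at the limit of > 10000 nM in this assay, at which 2 of the 2 values shown sit, with nothing to set it apart from compound 1. Compound 3, `Cc1c(C(N)=O)sc2ncnc(Nc3ccc(=O)n(C)c3)c12`, is not yet measured; it differs from compound 2 by amino in place of methoxy on a carbonyl carbon. Among the measured compounds shown here, no measured step covers such a change, and the step that the limit leaves unreadable from compound 2 to compound 3 is expected to stay within the scatter. Compound 3 is expected at 15000 nM, within 4000 nM to 60000 nM.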

Compound 3, inhibition constant: 4510 nM
Compound 3: the middle estimate sits 3.3-fold (0.52 log units) above what was measured; low and high end bracket the measured number.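

At this position, on a carbonyl carbon attached to an aromatic carbon, the change from methoxycarbonyl to carbamoyl gives an at least 2.2-fold lower number from compound 2 to compound 3 (0.34 log units; beyond the scatter). Among the compounds shown here, it also yields the first actual number in this assay, with compound 3 at 4510 nM. The true size of the step remains unknown, as compound 2 gives only a limit: the limit of > 10000 nM in this assay, at which 2 of the 3 values shown sit.

The compounds shown leave open how a methylamino group or a hydroxy group, which would make a carboxylic acid, would read on the same carbonyl carbon. A single pair also cannot show whether this change would act the same way on another compound.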